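A fluoro step on a highly bound compound

The source may report more compounds than this note shows. Statements on the series, on what has been measured and on what is new or still open speak of the compounds shown alone.

- compound 1 `COC(=O)NC12CCC(n3cc(-c4ccc(Cl)c(N)c4)c4c(N)ncnc43)(CC1)CC2` gives 99.6% of binding
- compound 2 `COC(=O)N[C@H]1CC[C@@H](n2cc(-c3ccc(Cl)c(N)c3)c3c(N)ncnc32)CC1` gives 96.9% of binding

In an ADME assay on a cell-free system (plasma, Mus musculus) for protein binding, read by LC-MS, using equilibrium dialysis, with a stated time of 16 h, tested at 5 uM, compound 1 has the lowest unbound fraction of the two, and its gap to compound 2 lies beyond the scatter. Compound 3 `COC(=O)NC12CCC(n3cc(-c4cc(N)c(Cl)cc4F)c4c(N)ncnc43)(CC1)CC2` differs from compound 1 by fluoro in place of hydrogen on an aromatic carbon in the form of fluoro in place of hydrogen on an aromatic carbon. For the measured compounds named here, no measured pair shows this change. The expected a 1.3-fold lower unbound fraction from compound 1 to compound 3 (0.12 log units; within the scatter) is therefore small, leaning slightly towards more binding and not beyond the scatter. Compound 3 is estimated at 99.7% with a range of 99% to 99.9% expected.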

Compound 3, plasma protein binding: 99.4%
Compound 3: middle estimate off by 2.0-fold (0.30 log units) (unbound fraction), on the low side; measured number inside the range.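

Fluoro in place of hydrogen, on the aromatic carbon ortho to a large group, gives a 1.5-fold higher unbound fraction from compound 1 to compound 3 (0.18 log units; within the scatter) in this assay and so shows that this position takes fluoro without a shift in binding beyond the scatter. The earlier compounds shown here could not show this, since both carry hydrogen there. Nothing at hand explains the result. Still open, as far as these compounds go, is whether a larger group at this position, such as methoxy or a nitrile, would shift binding beyond the scatter, and whether fluoro would behave alike on the core of compound 2.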